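Cytotoxicity notes: from compound 3 to compound 4

The source may report more compounds than this note shows. Statements on the series, on what has been measured and on what is new or still open speak of the compounds shown alone.

Measured in an ADME assay on HepG2 cells (Homo sapiens) for cytotoxicity, read by luminescence, CellTiter-Glo and ATP content, with a stated time of 72 h; on this read-out higher numbers stand for an effect only at larger amounts of compound and lower numbers for an effect already at smaller amounts:
compound 1 `COc1ccc(Oc2ccc3c(NCCCNCc4cc(F)ccc4OC)ccnc3c2)cc1`: 7000 nM
compound 2 `COc1ccc(F)cc1CNCCCNc1ccnc2cc(-c3ccc(F)cc3)ccc12`: 770 nM
compound 3 `COc1ccc(F)cc1CNCCCNc1ccnc2cc(Cc3cccc(C(F)(F)F)c3)ccc12`: 440 nM

Compound 3 stands at 440 nM, and the step of a 1.8-fold lower number from compound 2 to compound 3 (0.24 log units; within the scatter) does not separate it from compound 2. Compound 1 is well apart from it, with a 16-fold lower number from compound 1 to compound 3 (1.20 log units; beyond the scatter).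

Compound 4 `COc1ccc(F)cc1CNCCCNc1ccnc2cc(Oc3ccc(Cl)cc3)ccc12` carries 4-chlorophenoxy in place of 3-(trifluoromethyl)benzyl on an aromatic carbon. Among the compounds with values here, compound 1 is the only measured compound with a phenoxy-type group, so it offers the closest guide. Both measured steps away from its 4-methoxyphenoxy lowered the number: a 9.1-fold lower number from compound 1 to compound 2 (0.96 log units; beyond the scatter), as well as the step to compound 3 above. Within the data shown here, compound 4 reverses that kind of change, but no measured step compares 4-chlorophenoxy with 4-methoxyphenoxy, so only part of the gap is expected to return. In this assay the expected move is a 3.4-fold higher number from compound 3 to compound 4 (0.53 log units; beyond the scatter), a modest rise in the number. For compound 4 the estimated value is 1500 nM, with an expected range of 450 nM to 5000 nM.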

Compound 4, half-maximal effective concentration: 4500 nM
Beside the measured number, compound 4's estimate is 3.0-fold (0.48 log units) below it, and the stated range covers the measured number.
By their numbers in this assay, from the lowest: compounds 3 and 2 (each within the scatter of the next); then compounds 4 and 1 (each within the scatter of the next).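

In this assay, the second phenoxy-type group lands with the first: a 1.6-fold lower number from compound 1 to compound 4 (0.19 log units; within the scatter), so chloro in place of methoxy on this group gives no readable change. Compound 4 stands apart from the groups without the phenoxy link, with a 10-fold higher number from compound 3 to compound 4 (1.01 log units; beyond the scatter) and a 5.8-fold higher number from compound 2 to compound 4 (0.77 log units; beyond the scatter); among these four compounds, the two phenoxy-type groups give the higher numbers, the 4-fluorophenyl and 3-(trifluoromethyl)benzyl groups the lower, and no compound shown goes against this. Nothing measured here explains this split.

As far as these compounds go, the oxygen link and the ring substituent change together in these steps, so it remains open whether a 4-chlorobenzyl group would fall with compound 4 or with compound 3. Where an anilino link or a carboxylic acid on the phenoxy ring would fall is also open.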